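The Same Methoxy Change Carried Onto a Second Core

A few compounds are considered here, and "the series" means these few. Any claim that something is new, unique, unknown or untested is made for them only; others in the source may bear on it.

Three compounds have so far been measured in an ADME assay on RD cells (Homo sapiens) for cytotoxicity, read by MTT assay, with a stated time of 3 days; on this read-out higher numbers stand for lower toxicity in this test and lower numbers for higher toxicity in this test:

compound 1 `CC[C@H](CCn1cncn1)c1ccccc1`, which gives 99.8 ug/mL;
compound 2 `CC[C@H](CCn1cncn1)c1ccc(OC)cc1`, which gives 118 ug/mL;
compound 3 `c1ccc(C[C@@H](CCn2cncn2)c2ccccc2)cc1`, which gives 56 ug/mL.

Compound 2 differs from compound 1 by methoxy in place of hydrogen on an aromatic carbon. In this assay this change gave a 1.2-fold higher number from compound 1 to compound 2 (0.07 log units; within the scatter), so the two compounds cannot be told apart on this read-out. Compound 3 is built on a different core, and the difference between its core and that of compound 1 is not broken down here. The values of compound 3 and compound 1 lie within the scatter of each other, while the gap between compound 3 and compound 2 lies beyond it.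

Compound 4 `COc1ccc([C@H](CCn2cncn2)Cc2ccccc2)cc1` has not yet been measured. It differs from compound 3 by methoxy in place of hydrogen on an aromatic carbon, which is the same change as that from compound 1 to compound 2, made at the same kind of place, now on the core of compound 3. For the measured compounds named here, the one earlier instance of this change, a 1.2-fold higher number from compound 1 to compound 2 (0.07 log units; within the scatter), stayed within the scatter, and nothing among the measured compounds points to a different outcome on the second core. Compound 4 is therefore expected to stay close to compound 3, with an estimated step of a 1.2-fold higher number from compound 3 to compound 4 (0.06 log units; within the scatter). Compound 4 is expected to give about 65 ug/mL in this assay, most likely between 35 ug/mL and 120 ug/mL, because compound 3 gives 56 ug/mL and the earlier step was a 1.2-fold higher number from compound 1 to compound 2 (0.07 log units; within the scatter).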

Compound 4, half-maximal cytotoxic concentration: 66 ug/mL
The estimate for compound 4 lay 1.0-fold (0.01 log units) below the measured number; low and high end bracket the measured number.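

In this assay, methoxy in place of hydrogen on an aromatic carbon, para to a large group, gave a 1.2-fold higher number from compound 3 to compound 4 (0.07 log units; within the scatter). Set beside the earlier instance on the core of compound 1, the change carried from one core to the other with no difference that can be told apart: the same change on two cores in this assay, a 1.2-fold higher number (0.07 log units; within the scatter) from compound 1 to compound 2 and a 1.2-fold higher number (0.07 log units; within the scatter) from compound 3 to compound 4, 1.0-fold (0.00 log units) apart, within the scatter of two such steps. This shows that on both cores the two compounds of each pair cannot be separated on this read-out, but it does not show that methoxy has any effect of its own here, and two pairs say nothing about a third core or about any other test.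

The compounds shown leave open whether a different group at the same place, such as an amine, a carboxylic acid or a hydroxyl, would carry a step beyond the scatter on either core. They also leave open whether the same agreement between steps would hold on a core bearing a longer chain.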